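A few compounds are considered here, and "the series" means these few. Any claim that something is new, unique, unknown or untested is made for them only; others in the source may bear on it.

Among the compounds with values here, in a functional assay on MDA-MB-231 cells (Homo sapiens) for inhibition, read by MTT assay, with a stated time of 48 h (on this read-out lower numbers stand for stronger inhibition of growth and higher numbers for weaker inhibition of growth), compound 1 (`S=C(Nc1ccc(Cl)c(Cl)c1)Nc1ccc2ncnc(Nc3cccc(Br)c3)c2c1`) gives 4800 nM, the only full number so far. Compound 2 (`O=C(NCc1ccccc1)Nc1ccc2ncnc(Nc3cccc(Br)c3)c2c1`) reads > 30000 nM, which is a limit of the assay and not a number. Compound 3 (`O=C(Nc1ccc(Cl)cc1)Nc1ccc2ncnc(Nc3cccc(Br)c3)c2c1`) follows from compound 2 by 4-chlorophenyl in place of benzyl on an amide-type nitrogen, with 4-chlorophenyl in place of benzyl on an amide-type nitrogen. Within the data shown here, no measured step covers this change, so the size of the shift in this assay is poorly constrained. A moderate move towards stronger inhibition of growth is expected, though a second reading at the limit remains possible. The expected change is an at least 2.5-fold lower number from compound 2 to compound 3 (0.39 log units; beyond the scatter). The only numerical anchor for this expectation is compound 1 at 4800 nM. Compound 3 is estimated at 12000 nM, with an expected range of 4000 nM to 30000 nM.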

Compound 3, concentration for 50% growth inhibition: 10000 nM
Compound 3: the middle estimate sits 1.2-fold (0.08 log units) above what was measured; the measured number falls inside the stated range.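

On this amide-type nitrogen, 4-chlorophenyl in place of benzyl gives an at least 3.0-fold lower number from compound 2 to compound 3 (0.47 log units; beyond the scatter), so the position responds to this change in this assay. The two groups carry the same count of heavy atoms and each holds one six-membered aromatic ring of carbon only, so the step does not come from a change in group size by that count. Compound 2 reads > 30000 nM, a limit of the assay and not a number, and the true size of the step stays unknown because of that limit: the limit of > 30000 nM in this assay, at which 1 of the 3 values shown sits.

As far as these compounds go, whether the step belongs to the chlorine or to the change from benzyl to a ring set directly on the nitrogen remains open, and a plain phenyl group here would separate the two. From the compounds shown here alone, how a longer chain such as phenylethyl, or an amine, would read on this nitrogen also remains open.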